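Extending a sulfur-linked chain: what compound 3 may do

The compounds below may be only part of what the source reports. "The series", "measured", "known", "first", "only" and "open" are said of these compounds alone.

Measured in a functional assay on MOLT-3 cells (Homo sapiens); on this read-out lower numbers stand for stronger inhibition and higher numbers for weaker inhibition:
Compound 1 `CCSC[C@H](NC(C)=O)C(=O)CCl` gives 99900 nM
Compound 2 `CCCCCSC[C@H](NC(C)=O)C(=O)CCl` gives 5400 nM

Compound 1 holds the higher of the two numbers, which makes it the weaker inhibitor of this pair. Compound 3 `CCCCCCCSC[C@H](NC(C)=O)C(=O)CCl` has not yet been measured. It carries pentyl in place of hydrogen on a saturated chain carbon, two bonds along the chain from a sulfur. Going by the values given here, one measured step bears on this change: a 19-fold lower number from compound 1 to compound 2 (1.27 log units; beyond the scatter) (large and beyond the scatter), with propyl replacing hydrogen at that same place. Pentyl is the longer chain, so a large step to a lower number is expected again in this assay, although a single step cannot show how far this trend runs. The estimated step is a 67-fold lower number from compound 1 to compound 3 (1.82 log units; beyond the scatter) on this reasoning. For compound 3 the estimated value is 1500 nM with an expected range from 300 nM to 6000 nM for now.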

Compound 3, half-maximal inhibitory concentration: 2500 nM
For compound 3 the middle estimate is 1.7-fold (0.22 log units) below the measured one, and the stated range covers the measured number.
By their numbers in this assay, from the lowest: compound 3; then compound 2; then compound 1.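

In this assay, the trend seen with compound 2 continues: lengthening the chain on the sulfur gives a 40-fold lower number from compound 1 to compound 3 (1.60 log units; beyond the scatter), and none of the three compounds goes against it. The added length pays off less at this stage, though, as the ethyl extension gives only a 2.2-fold lower number from compound 2 to compound 3 (0.33 log units; beyond the scatter), a modest change that is beyond the scatter but far smaller than a 19-fold lower number from compound 1 to compound 2 (1.27 log units; beyond the scatter). No supporting data are available to explain why the step shrinks.

As far as these compounds go, it remains open whether a longer chain than that of compound 3 would lower the number further, level off or reverse the trend. From the compounds shown here alone, it is also open whether a chain ending in an amine or a carboxylic acid would follow the same trend as these plain carbon chains.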